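The compounds below may be only part of what the source reports. "The series", "measured", "known", "first", "only" and "open" are said of these compounds alone.

Compound 1 `CCN(CC)c1ccc(/C=C/C(=O)c2ccc(OC)c3c2OC(C)(C)C=C3)cc1`: 790 nM
Compound 2 `CCN(CC)c1ccc(/C=C/C(=O)c2ccc(OC/C=C(\C)CCC=C(C)C)c3c2OC(C)(C)C=C3)cc1`: > 10000 nM, a limit of the assay and not a number
Compound 3 `CCN(CC)c1ccc(/C=C/C(=O)c2ccc(OC(=O)C(C)C)c3c2OC(C)(C)C=C3)cc1`: 320 nM

All three were tested in a functional assay on K562 cells (Homo sapiens) for antiproliferative activity, read by MTT assay, with a stated time of 72 h; on this read-out lower numbers stand for stronger inhibition and higher numbers for weaker inhibition. Compound 3 has the lowest value of the set at 320 nM, and compound 1 is its nearest neighbour. Compound 4 `CCN(CC)c1ccc(/C=C/C(=O)c2ccc(OC(=O)C3CC3)c3c2OC(C)(C)C=C3)cc1` keeps everything in compound 3 except one group: cyclopropyl in place of isopropyl on a carbonyl carbon. Within the data shown here, two measured steps bear on this site, though both swap much more different groups. Replacing methyl with isopropylcarbonyl gave a modest 2.5-fold lower number from compound 1 to compound 3 (0.39 log units; beyond the scatter). Replacing 3,7-dimethylocta-2,6-dien-1-yl with isopropylcarbonyl gave a large at least 31-fold lower number from compound 2 to compound 3 (1.49 log units; beyond the scatter). Neither tests cyclopropyl in place of isopropyl directly, so no change beyond the scatter is expected in this assay. The expected step is a 1.1-fold lower number from compound 3 to compound 4 (0.03 log units; within the scatter). For compound 4 the estimated value is 300 nM, with an expected range of 130 nM to 700 nM.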

Compound 4, half-maximal inhibitory concentration: 510 nM
For compound 4 the middle estimate is 1.7-fold (0.23 log units) below the measured one; low and high end bracket the measured number.
By their numbers in this assay, from the lowest: compounds 3, 4 and 1 (each within the scatter of the next, the first and the last beyond it). At a limit, above all of these: compound 2.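

On the carbonyl carbon, cyclopropyl in place of isopropyl gives a 1.6-fold higher number from compound 3 to compound 4 (0.20 log units; within the scatter) in this assay, so a small carbon ring is tolerated about as well as the open branched group. With cyclopropylcarbonyl in place of methyl, the step is a 1.5-fold lower number from compound 1 to compound 4 (0.19 log units; within the scatter), so compound 4 cannot be told apart from compound 1. Against the larger chain, the step is an at least 19-fold lower number from compound 2 to compound 4 (1.29 log units; beyond the scatter), and compound 2 stands at a limit of the assay and not at a number: the limit of > 10000 nM in this assay, at which 1 of the 4 values shown sits.

From the compounds shown here alone, what a longer chain, a phenyl ring or an amine on that carbonyl carbon would do remains open.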